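Swapping the diazepane for a pyrazolylamino group: solubility outlook

A few compounds are considered here, and "the series" means these few. Any claim that something is new, unique, unknown or untested is made for them only; others in the source may bear on it.

Measured so far in a physicochemical assay for solubility, read by LC-MS, in phosphate buffer, measured as thermodynamic solubility, with a stated time of 24 h, at pH 7.4; on this read-out higher numbers stand for higher solubility and lower numbers for lower solubility:
Compound 1, `Cc1nn(C)cc1-c1cnc2[nH]cc(-c3cccc(C#N)c3)c2c1`, gives 2000 nM.
Compound 2, `N#Cc1cccc(-c2c[nH]c3ncc(-c4cncnc4)cc23)c1`, gives 3000 nM.
Compound 3, `CN1CCCN(c2cnc3[nH]cc(-c4cccc(C#N)c4)c3c2)CC1`, gives 690000 nM.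

Compound 3 stands highest of the three in this assay, separated from both others by steps far beyond the scatter, as a 350-fold higher number from compound 1 to compound 3 (2.54 log units; beyond the scatter) and a 230-fold higher number from compound 2 to compound 3 (2.36 log units; beyond the scatter) show; compounds 1 and 2 lie close together, with a 1.5-fold higher number from compound 1 to compound 2 (0.18 log units; within the scatter). Compound 4, `Cn1cc(Nc2cnc3[nH]cc(-c4cccc(C#N)c4)c3c2)cn1`, is reached from compound 3 by (1-methyl-1H-pyrazol-4-yl)amino in place of 4-methyl-1,4-diazepan-1-yl on an aromatic carbon. Both large steps into compound 3 arose when 4-methyl-1,4-diazepan-1-yl replaced 1,3-dimethyl-1H-pyrazol-4-yl or pyrimidin-5-yl at this position, and compound 4 moves back toward a group built on a five-membered aromatic ring. For compound 4 a large drop in this assay is therefore expected, a 140-fold lower number from compound 3 to compound 4 (2.14 log units; beyond the scatter). Compound 4 is estimated at 5000 nM, with a range from 1500 nM to 20000 nM.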

Compound 4, solubility: 31000 nM
Estimate against measurement, compound 4: 6.2-fold (0.79 log units) below; the whole stated range lies below it.
By their numbers in this assay, from the lowest: compounds 1 and 2 (each within the scatter of the next); then compound 4; then compound 3.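

At this position, a group built on a five-membered aromatic ring need not sit at the low end in this assay: (1-methyl-1H-pyrazol-4-yl)amino gives a 10-fold higher number from compound 2 to compound 4 (1.01 log units; beyond the scatter) and a 16-fold higher number from compound 1 to compound 4 (1.19 log units; beyond the scatter). Unlike the groups in compound 1 and compound 2, it joins its ring to the core through an amino nitrogen. Even so, 4-methyl-1,4-diazepan-1-yl stays on top, with a 22-fold lower number from compound 3 to compound 4 (1.35 log units; beyond the scatter).

Nothing shown gives a reason for these steps. Also open, going by these compounds, is whether an N-methylamino link or a 4-methylpiperazin-1-yl group would give similar numbers.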